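Cyclobutyl for cyclopentyl on a carbonyl carbon

This account rests on a few compounds, and the source may have more. Where it says the series, first, only, none or still open, it means among the compounds named here.

Compound 1 (`O=C(c1ccccc1F)N1CCN(c2nc(=O)c3cc(C(F)(F)F)cc([N+](=O)[O-])c3s2)CC1`) and compound 2 (`O=C(C1CCCC1)N1CCN(c2nc(=O)c3cc(C(F)(F)F)cc([N+](=O)[O-])c3s2)CC1`) share a core and differ only in the group on a carbonyl carbon. For the measured compounds named here, in an ADME assay on Vero cells (Chlorocebus sabaeus) for cytotoxicity, read by MTT assay, with a stated time of 72 h (on this read-out lower numbers stand for higher toxicity in this test and higher numbers for lower toxicity in this test), compound 2 gives 120000 nM, the only true number so far. Compound 1 reads > 125000 nM, which is a limit of the assay and not a number.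

The next compound, compound 3 (`O=C(C1CCC1)N1CCN(c2nc(=O)c3cc(C(F)(F)F)cc([N+](=O)[O-])c3s2)CC1`), carries cyclobutyl in place of cyclopentyl on a carbonyl carbon. Going by the values given here, only one measured step bears on this change, namely an at least 1.0-fold lower number from compound 1 to compound 2 (0.01 log units; that floor lies within the scatter). It concerns the same place, but it replaces a different group and, resting on a limit, gives only a floor. Among the compounds with values here, nothing measured so far therefore points to a real shift in either direction, and no step beyond the scatter is expected in this assay. The estimated change is a 1.0-fold higher number from compound 2 to compound 3 (0.02 log units; within the scatter). The value expected for compound 3 is 125000 nM, with an estimated range of 75000 nM to 200000 nM.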

Compound 3, half-maximal cytotoxic concentration: > 125000 nM
Compound 3: no number, only a limit; the forecaster's own chance of this, stated with the estimate: 45%; the middle value sits exactly at the limit.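

In this assay, compound 3 reads > 125000 nM, which is a limit of the assay and not a number. Cyclobutyl in place of cyclopentyl on a carbonyl carbon gives an at least 1.0-fold higher number from compound 2 to compound 3 (0.01 log units; that floor lies within the scatter), so this change, the first here between two carbon-only non-aromatic rings, shows no step beyond the scatter, though its floor does not fix the size of the step. The step that joins compound 1 and compound 3 cannot be read, because the two values are both limits and the readings at this position gather at one point: the limit of > 125000 nM in this assay, at which 2 of the 3 values shown sit.

With only cyclopentyl, cyclobutyl and 2-fluorophenyl shown on this carbonyl carbon, it remains open whether any group there can bring the number in this assay down by more than the scatter. From the compounds shown here alone, a basic amine such as a piperidine, a carboxylic acid or a longer alkyl chain at the same place might answer that, and the true values of compound 1 and compound 3 also remain unknown.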